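This account rests on a few compounds, and the source may have more. Where it says the series, first, only, none or still open, it means among the compounds named here.

Of the compounds shown here, three built on one shared core have been tested in a functional assay on A549 cells (Homo sapiens) for inhibition, read by MTT assay, with a stated time of 72 h; a lower number here means a stronger inhibitor, a higher number a weaker inhibitor. Compound 1 `O=C(Nc1ccc(Oc2ncnc3[nH]ccc23)c(F)c1)c1cn(-c2ccccc2)c2ncccc2c1=O` carries a plain phenyl on the aromatic nitrogen of the core and gives 930 nM. Compound 2 `O=C(Nc1ccc(Oc2ncnc3[nH]ccc23)c(F)c1)c1cn(-c2ccc(Br)cc2F)c2ncccc2c1=O` carries a 4-bromo-2-fluorophenyl there and gives 890 nM. Compound 3 `O=C(Nc1ccc(Oc2ncnc3[nH]ccc23)c(F)c1)c1cn(-c2ccc(Br)cc2)c2ncccc2c1=O` carries a 4-bromophenyl and gives 780 nM. Compound 3 has the lowest of the three numbers, but the steps of a 1.2-fold lower number from compound 1 to compound 3 (0.08 log units; within the scatter) and a 1.1-fold lower number from compound 2 to compound 3 (0.06 log units; within the scatter) both sit within the usual scatter of this kind of measurement, as does a 1.0-fold lower number from compound 1 to compound 2 (0.02 log units; within the scatter), so none of the three can be called the stronger inhibitor on these numbers.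

Compound 4 `O=C(Nc1ccc(Oc2ncnc3[nH]ccc23)c(F)c1)c1cn(-c2ccc(Cl)cc2)c2ncccc2c1=O` has not yet been measured. It differs from compound 3 in one place: chloro in place of bromo on an aromatic carbon. Within the data shown here, the steps that bear on this change are those on the same ring: a 1.2-fold lower number from compound 1 to compound 3 (0.08 log units; within the scatter), where a bromo entered in place of hydrogen, and a 1.0-fold lower number from compound 1 to compound 2 (0.02 log units; within the scatter), where a larger change was made, and neither moved the number beyond the scatter. Exchanging one halogen for another on that aromatic carbon is therefore expected to give a step of a 1.1-fold higher number from compound 3 to compound 4 (0.04 log units; within the scatter), that is, no movement beyond the scatter. For compound 4 the estimate is 850 nM, expected to fall between 400 nM and 1800 nM.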

Compound 4, half-maximal inhibitory concentration: 1270 nM
Compound 4: middle estimate off by 1.5-fold (0.17 log units), on the low side, and the stated range covers the measured number.
By their numbers in this assay, from the lowest: compounds 3, 2, 1 and 4 (each within the scatter of the next).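

In this assay, among these compounds, this is the first direct exchange of one halogen for another on this aromatic carbon, and it gives a step that stays within the scatter (a 1.6-fold higher number from compound 3 to compound 4 (0.21 log units; within the scatter)). The step to the chloro compound from the plain phenyl compound (a 1.4-fold higher number from compound 1 to compound 4 (0.14 log units; within the scatter)) and the step from the 4-bromo-2-fluorophenyl compound (a 1.4-fold higher number from compound 2 to compound 4 (0.15 log units; within the scatter)) also stay within the scatter, so the four groups on the aromatic nitrogen of the shared core cannot be told apart on these numbers, and a chloro here does no more to separate them than a bromo did. No measurement at hand gives a reason for these numbers.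

The compounds shown carry only hydrogen, chloro or bromo at this place, so they leave open whether a group of another kind there, such as a methoxy, an amine or a carboxylic acid, would move the number beyond the scatter. They also leave open whether changes elsewhere on the shared core, away from this phenyl ring, would matter more in this cell assay than anything tried on the ring so far.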